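Changing the selenium group of compound 2

A few compounds are considered here, and "the series" means these few. Any claim that something is new, unique, unknown or untested is made for them only; others in the source may bear on it.

In a functional assay on MDA-MB-231 cells (Homo sapiens) for inhibition, read by MTT assay, with a stated time of 48 h (a lower number here means a stronger inhibitor, a higher number a weaker inhibitor), compound 1 `Cc1nc(N(C)c2ccc([Se]C#N)c(C)c2)c2ccccc2n1` gives 16 nM and compound 2 `COc1ccc(N(C)c2nc(C)nc3ccccc23)cc1[Se]C` gives 10 nM. For the measured compounds named here, these two numbers lie within the usual scatter of each other, so compound 2 stands level with the only other compound measured so far. Compound 3 `COc1ccc(N(C)c2nc(C)nc3ccccc23)cc1C[Se]C#N` keeps the shared core of compound 2 and alters one group on an aromatic carbon, ortho to a methoxy group and meta to a large group: a group of 4 heavy atoms (2 carbon, 1 nitrogen, 1 selenium; no ring) in place of a group of 2 heavy atoms (1 carbon, 1 selenium; no ring), on an aromatic carbon. Going by the values given here, no measured pair isolates this change, so any expectation is indirect. Compound 1 also carries selenium and a nitrile and gives 16 nM, so only a small rise in the number, not clearly beyond the scatter, is expected in this assay. The expected step is a 2.0-fold higher number from compound 2 to compound 3 (0.30 log units; within the scatter). Compound 3 is estimated at 20 nM, with an expected range of 5 nM to 80 nM.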

Compound 3, half-maximal inhibitory concentration: 153 nM
The estimate for compound 3 lay 7.7-fold (0.88 log units) below the measured number, and the stated range ends below it.
By their numbers in this assay, from the lowest: compounds 2 and 1 (each within the scatter of the next); then compound 3.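

At this aromatic carbon, ortho to a methoxy group and meta to a large group, the selenium group clearly matters: in this assay, the exchange of the group of 2 heavy atoms for the group of 4 heavy atoms gives a 15-fold higher number from compound 2 to compound 3 (1.18 log units; beyond the scatter). The earlier compounds shown here could not show this, since they stood level with each other and differ in more than one place, so neither gave any reading of how this carbon responds to a change in its group. Nothing measured here accounts for the size of the step.

The extra carbon and the nitrile enter together, so the compounds shown do not separate their contributions to the step. On these data alone, how a group without selenium, such as an ethyl chain or a primary amine, would fare on this carbon also remains open.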